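Ring size and linker change at the amine side chain

The compounds below may be only part of what the source reports. "The series", "measured", "known", "first", "only" and "open" are said of these compounds alone.

Three compounds share one core. Compound 1 `CN(C)CCn1nc(Cc2ccc(Cl)cc2)c2ccccc2c1=O` gives 158 nM in an assay for binding affinity to Alpha-1A adrenergic receptor (Homo sapiens); on this read-out higher numbers stand for weaker inhibition and lower numbers for stronger inhibition. Compound 2 `CN1CCC(Cn2nc(Cc3ccc(Cl)cc3)c3ccccc3c2=O)C1` gives 100 nM, and compound 3 `CN1CCC[C@@H]1Cn1nc(Cc2ccc(O)cc2)c2ccccc2c1=O` gives 251 nM. Compound 2 holds the lowest of the three numbers, with compound 1 within the scatter of it and compound 3 beyond it. Within the data shown here, the one step measured at the amine side, a 1.6-fold lower number from compound 1 to compound 2 (0.20 log units; within the scatter), shows that swapping one basic amine group for another moved the number very little.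

Compound 4 `CN1CCCCC(n2nc(Cc3ccc(Cl)cc3)c3ccccc3c2=O)C1` is not yet measured. It differs from compound 2 in one place: 1-methylazepan-3-yl in place of (1-methylpyrrolidin-3-yl)methyl on an aromatic nitrogen. The ring grows from five to seven members and sits directly on the aromatic nitrogen without the intervening carbon. Among the measured compounds shown here, only the step from compound 1 to compound 2 bears on this kind of change, and it stayed within the scatter, so a small step is expected, in either direction. For compound 4 the estimate is 130 nM, with a range from 50 nM to 350 nM, meaning a step of a 1.3-fold higher number from compound 2 to compound 4 (0.11 log units; within the scatter) is expected.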

Compound 4, inhibition constant: 158 nM
Compound 4: the middle estimate sits 1.2-fold (0.08 log units) below what was measured; the measured number falls inside the stated range.
By their numbers in this assay, from the lowest: compounds 2, 1, 4 and 3 (each within the scatter of the next, the first and the last beyond it).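

In this assay the seven-membered ring of 1-methylazepan-3-yl, set directly on the aromatic nitrogen, changes little: replacing (1-methylpyrrolidin-3-yl)methyl gives a 1.6-fold higher number from compound 2 to compound 4 (0.20 log units; within the scatter) and replacing 2-(dimethylamino)ethyl gives no change at the digits printed from compound 1 to compound 4 (within the scatter) on the same core. An open chain, a five-membered ring on a one-carbon link and a seven-membered ring with no link therefore all read alike at this position, within the scatter of one another. No measurement at hand offers a reason for this sameness.

From the compounds shown here alone, whether a 1-methylpiperidin-3-yl group, with its six-membered ring, would also fit this pattern remains open. So does the question of whether the number would hold if the amine gave way to a carboxylic acid on a longer chain.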